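The compounds below may be only part of what the source reports. "The series", "measured", "known", "first", "only" and "open" are said of these compounds alone.

Compound 1, `CO[C@H]1CC=C2CCN(C)[C@H]2C1`, gives 100000 nM in an assay on HEK293 cells for displacement of a labelled ligand from Neuronal acetylcholine receptor; alpha4/beta4 (Rattus norvegicus), with a stated time of 4 h; on this read-out lower numbers stand for stronger inhibition and higher numbers for weaker inhibition.
Compound 2, `CCO[C@H]1CC=C2CCN(C)[C@H]2C1`, gives > 300000 nM in this assay, a limit of the assay rather than a number.
Compound 3, `COCCO[C@H]1CC=C2CCN(C)[C@H]2C1`, gives > 300000 nM in this assay, again a limit of the assay.

Among the compounds with values here, compound 1 thus stands as the only compound with a measured number; the other two readings sit at the limit of > 300000 nM in this assay, at which 2 of the 3 values shown sit. The steps away from it are an at least 3.0-fold higher number from compound 1 to compound 2 (0.47 log units; beyond the scatter) and an at least 3.0-fold higher number from compound 1 to compound 3 (0.47 log units; beyond the scatter), both on the ether chain.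

Compound 4, `CO[C@H]1CC=C2CCN[C@H]2C1`, differs from compound 1 in one place: hydrogen in place of methyl on an amine nitrogen in a ring. No measured step touches the amine nitrogen, so nothing shown bears on this change. No step beyond the scatter is therefore expected, which means no change at the digits printed from compound 1 to compound 4 (within the scatter). Compound 4 is estimated at 100000 nM, within a range from 30000 nM to 300000 nM.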

Compound 4, inhibition constant: > 300000 nM
Compound 4 gave a limit, no number (the forecaster's own chance of this, stated with the estimate: 35%); middle value at least 3.0-fold (0.47 log units) away from the limit.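

Hydrogen in place of methyl on the amine nitrogen in a ring is the first change shown at this position, and it gives an at least 3.0-fold higher number from compound 1 to compound 4 (0.47 log units; beyond the scatter). The methyl on this nitrogen therefore matters in this assay, and removing it moves the reading towards weaker inhibition, as the two changes on the ether chain did. Compound 4 gives a limit and not a number, so the true size of the step cannot be read, and the data now rest mostly on that same limit: the limit of > 300000 nM in this assay, at which 3 of the 4 values shown sit.

Going by these compounds, whether an ethyl group or a longer chain on this nitrogen would give a lower number than compound 1 stays open.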